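Swapping a methyl for 4-fluorophenyl on a kinase inhibitor core

The source may report more compounds than this note shows. Statements on the series, on what has been measured and on what is new or still open speak of the compounds shown alone.

This study measures an assay on 786-0 cells for inhibition of phosphatidylinositol 4,5-bisphosphate 3-kinase catalytic subunit beta isoform (Homo sapiens), with a stated time of 1 h; a higher number here means a weaker inhibitor, a lower number a stronger inhibitor. Within the data shown here, compound 1, `C[C@H](Nc1nc(N)nc(N)c1C#N)c1c(-c2ccccc2)c(=O)n2cc(F)ccc2c1-c1ccc(F)cc1`, is the only measured compound, and in this assay compound 1 gives 208 nM. Compound 2, `Cc1nc(N)nc(N[C@@H](C)c2c(-c3ccccc3)c(=O)n3cc(F)ccc3c2C)c1C#N`, shares much of the same core, but in this assay compound 2 gives "not determined" (no result reported), so compound 2 stands without a number.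

Compound 3, `Cc1nc(N)nc(N[C@@H](C)c2c(-c3ccccc3)c(=O)n3cc(F)ccc3c2-c2ccc(F)cc2)c1C#N`, has not been measured yet. Compound 3 differs from compound 2 in one place: 4-fluorophenyl in place of methyl on an aromatic carbon. Among the measured compounds shown here, because no pair of measured compounds shows this change, the size and direction of the step from compound 2 to compound 3 in this assay cannot be read from the data; the only guide is that compound 1, which also carries a 4-fluorophenyl group at the same spot, gives 208 nM in this assay. That value suggests the 4-fluorophenyl group is compatible with meaningful inhibition, though compound 1 and compound 3 also differ elsewhere. On that basis compound 3 is expected to give about 300 nM in this assay, within a range of 80 nM to 1200 nM.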

Compound 3, half-maximal inhibitory concentration: 78 nM
Compound 3: middle estimate off by 3.8-fold (0.59 log units), on the high side, outside the stated range (below it).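

With 4-fluorophenyl held in place on the shared core, the new measurement isolates a second site: in this assay, methyl in place of amino on an aromatic carbon gives a 2.7-fold lower number from compound 1 to compound 3 (0.43 log units; beyond the scatter), a modest gain that lies beyond the usual scatter and shows that this other site still influences inhibition when 4-fluorophenyl is present. The effect of 4-fluorophenyl in place of methyl itself still cannot be read, since compound 2 has no number to compare with compound 3, so the data show only that inhibition is retained with 4-fluorophenyl at this position, not whether that group helps or harms it. Nothing available explains why the methyl compound gives the lower number.

Going by these compounds, it remains open how a chlorine atom or an ethyl group would compare with the methyl on that aromatic carbon, and whether an unsubstituted cyclohexyl ring or a morpholine could stand in for 4-fluorophenyl. A numerical result for a partner carrying only methyl at the 4-fluorophenyl position would be needed to give that swap a size and a direction.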